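Aryl Swap at the Saturated Ring Carbon: Compound 3

The source may hold more compounds than are shown below. What is called first, only, known or untested is meant among the compounds shown, and "the series" means these compounds.

Compound 1 `COc1cc(N2C(N)=C(C#N)C(/C=C/c3ccccc3)C3=C2CC(C)(C)CC3=O)cc(OC)c1OC` gives 30% in a functional assay on Ehrlich cells (Mus musculus) for cytotoxicity, tested at 50 ug/mL; on this read-out lower numbers stand for a weaker effect and higher numbers for a stronger effect at the one concentration tested.
Compound 2 `COc1cc(N2C(N)=C(C#N)C(c3ccccc3Cl)C3=C2CC(C)(C)CC3=O)cc(OC)c1OC` gives 20% in this assay.

Within the data shown here, compound 2 holds the lower of the two numbers, with compound 1 as its only neighbour; the step of a number 10 percentage points lower from compound 1 to compound 2 (within the scatter) lies within the scatter. Compound 3 `COc1cc(N2C(N)=C(C#N)C(c3ccc(O)cc3)C3=C2CC(C)(C)CC3=O)cc(OC)c1OC` differs from compound 2 by one change: 4-hydroxyphenyl in place of 2-chlorophenyl on a saturated ring carbon. Among the measured compounds shown here, no measured step covers this change; the only step known, from compound 1 to compound 2, was itself within the scatter. Compound 3 is therefore expected to stay near compound 2 in this assay, with a step of a number 2 percentage points higher from compound 2 to compound 3 (within the scatter) meaning no shift beyond the scatter. The estimate for compound 3 is 22%, ranging from 8% to 40%.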

Compound 3, a percentage reported as activity, at one concentration (the size of the read-out at that concentration, not a potency): 90%
Estimate against measurement, compound 3: 68 percentage points below, outside the stated range (above it).
By their numbers in this assay, from the lowest: compounds 2 and 1 (each within the scatter of the next); then compound 3.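

In this assay, the saturated ring carbon turns out to be sensitive to what it carries: the earlier swap stayed within the scatter, but 4-hydroxyphenyl in place of 2-chlorophenyl gives a number 70 percentage points higher from compound 2 to compound 3 (beyond the scatter), and in place of 2-phenylethenyl gives a number 60 percentage points higher from compound 1 to compound 3 (beyond the scatter). Both steps are large, so compound 3 stands clearly apart from the other two. Nothing available explains this rise.

As far as these compounds go, it remains open whether the rise follows the hydroxyl group itself or the substituent's place on the phenyl ring. Compounds bearing 4-chlorophenyl, 2-hydroxyphenyl or 4-methoxyphenyl at this carbon would separate these readings.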